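Sulfo in place of carboxy on an aromatic carbon

A few compounds are considered here, and "the series" means these few. Any claim that something is new, unique, unknown or untested is made for them only; others in the source may bear on it.

The compounds so far in an ADME assay on MDCKII-LE cells (Canis lupus familiaris) for permeability (a lower number here means that the compound crosses the layer more slowly, a higher number that the compound crosses the layer faster), are these:
- compound 1 `O=C(O)c1ccc(NC(=O)[C@H](CC2CCCC2)n2cnc(C(F)(F)F)c2)nc1` gives 1 10^-6 cm/s
- compound 2 `O=C(O)c1cccc(NC(=O)[C@H](CC2CCCC2)n2cnc(C(F)(F)F)c2)n1` gives 0.7 10^-6 cm/s
- compound 3 `O=C(O)c1ccnc(NC(=O)[C@H](CC2CCCC2)n2cnc(C(F)(F)F)c2)c1` gives "not determined" (no result reported)

For the measured compounds named here, compound 1 has only one numerical neighbour, and the two values do not truly separate: the comparison is a 1.4-fold lower number from compound 1 to compound 2 (0.15 log units; within the scatter) and compound 3 offers no number. The next compound, compound 4 `O=C(Nc1ccc(S(=O)(=O)O)cn1)[C@H](CC1CCCC1)n1cnc(C(F)(F)F)c1`, keeps the core of compound 1 but carries sulfo in place of carboxy on an aromatic carbon. Going by the values given here, the one measured step only swaps 5-carboxypyridin-2-yl for 6-carboxypyridin-2-yl, so the carboxy group stays. Among the compounds with values here, it therefore offers no direct guide to replacing that group, and no measured compound carries sulfo. The forecast is thus a cautious one, with a wide range. A modest fall is expected in this assay, with the estimated step being a 2.5-fold lower number from compound 1 to compound 4 (0.40 log units; beyond the scatter) and a rise not ruled out. The estimate for compound 4 is 0.4 10^-6 cm/s (expected range 0.1 10^-6 cm/s to 1.2 10^-6 cm/s).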

Compound 4, apparent permeability: 0.7 10^-6 cm/s
Beside the measured number, compound 4's estimate is 1.8-fold (0.24 log units) below it, and the stated range covers the measured number.
By their numbers in this assay, from the lowest: compounds 2, 4 and 1 (each within the scatter of the next).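

For the compounds shown here, the one earlier step in this assay only exchanged 5-carboxypyridin-2-yl for 6-carboxypyridin-2-yl, so compound 4 is the first to replace the carboxy group itself. On this aromatic carbon, two atoms from the ring nitrogen and para to a large group, sulfo in place of carboxy gives a 1.4-fold lower number from compound 1 to compound 4 (0.15 log units; within the scatter) and so leaves compound 1 and compound 4 unseparated in this assay. No measurement is available here that would explain this result.

As far as these compounds go, it remains open whether other groups at this place, such as a tetrazole or a methyl ester, would also stay within the scatter of compound 1 or would separate from it. Also open, from the compounds shown here alone, is how sulfo would read at the places the carboxy group holds in compound 2 and compound 3.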